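Working notes: cytotoxicity of a shared-core series

A few compounds are considered here, and "the series" means these few. Any claim that something is new, unique, unknown or untested is made for them only; others in the source may bear on it.

Measured in a functional assay on RD cells (Homo sapiens) for inhibition, read by luminescence and ATP content, with a stated time of 72 h; on this read-out lower numbers stand for higher toxicity in this test and higher numbers for lower toxicity in this test:
compound 1 `Cc1nc(-c2cnc3ccc(-c4ccccc4)cc3c2)no1` gives > 2500 nM.
compound 2 `Cc1nc(-c2cnc3ccc(-c4ccc(O)cc4)cc3c2)no1` gives > 2500 nM.
compound 3 `CCc1nc(-c2cnc3ccc(-c4ccccc4)cc3c2)no1` gives > 7400 nM.

The value of compound 1 is a limit of the assay. The value of compound 2 is a limit of the assay. The value of compound 3 is a limit of the assay. Two values sit at one limit (the limit of > 2500 nM in this assay, at which 2 of the 3 values shown sit), one at another (the limit of > 7400 nM in this assay, at which 1 of the 3 values shown sits).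

The change hydroxy in place of hydrogen on an aromatic carbon gives the step that the two limits leave unreadable from compound 1 to compound 2, which the two limits leave unreadable. The cores of compound 1 and compound 3 differ by methyl in place of hydrogen on a saturated chain carbon bound to an aromatic carbon, the step being a step that the two limits leave unreadable from compound 1 to compound 3.

Compound 4 `CCc1nc(-c2cnc3ccc(-c4ccc(O)cc4)cc3c2)no1` carries the same change as compound 2, (hydroxy in place of hydrogen on an aromatic carbon). In this assay the step that the limit leaves unreadable from compound 3 to compound 4 is expected to be small, resting on compound 1 and compound 2 both sitting at the limit of > 2500 nM in this assay, at which 2 of the 3 values shown sit, and on compound 3 already at the limit of > 7400 nM in this assay, at which 1 of the 3 values shown sits. Compound 4 is estimated at 10000 nM, most likely reported only as a limit.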

Compound 4, half-maximal cytotoxic concentration: > 2500 nM
Compound 4 ended at the assay's limit; the forecaster's own chance of this, stated with the estimate: 75%; the middle value does not contradict the limit.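

In this assay, the steps from compound 3 to compound 4 and from compound 2 to compound 4 cannot be read, as all three values are limits. The compounds shown leave open whether either change affects toxicity in this test.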